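Aryl amide variation on a weakly antiproliferative anilide series

This account rests on a few compounds, and the source may have more. Where it says the series, first, only, none or still open, it means among the compounds named here.

Compound 3 `O=C(Nc1ccc(Cl)c(-c2nnc3c(Cl)cccn23)c1)c1ccon1` carries a 1,2-oxazol-3-yl group on the carbonyl carbon of the amide. In a functional assay on MCF7 cells (Homo sapiens) for antiproliferative activity, read by MTT assay, with a stated time of 72 h (on this read-out higher numbers stand for weaker inhibition and lower numbers for stronger inhibition), compound 3 gives only a limit, > 100000 nM; this is a limit of the assay and not a number (the limit of > 100000 nM in this assay, at which 1 of the 3 values shown sits). The two measured relatives show where this sits. Compound 1 `O=C(Nc1ccc(Cl)c(-c2nnc3c(Cl)cccn23)c1)c1ccccn1`, with pyridin-2-yl at the same carbonyl, gives 96400 nM in this assay. Compound 2 `O=C(Nc1ccc(Cl)c(-c2nnc3c(Cl)cccn23)c1)c1ccc(Cl)cc1Cl`, with 2,4-dichlorophenyl there, gives 78200 nM. The steps of a 1.2-fold lower number from compound 1 to compound 2 (0.09 log units; within the scatter), an at least 1.0-fold higher number from compound 1 to compound 3 (0.01 log units; that floor lies within the scatter) and an at least 1.2-fold higher number from compound 2 to compound 3 (0.10 log units; that floor lies within the scatter) all stay within the scatter, so the three aryl groups on the carbonyl carbon are indistinguishable on this read-out.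

Compound 4 `O=C(Nc1ccc(Cl)c(-c2nnc3c(Cl)cccn23)c1)c1cccnc1Cl` differs from compound 3 by 2-chloropyridin-3-yl in place of 1,2-oxazol-3-yl on a carbonyl carbon. Of the measured steps, an at least 1.0-fold higher number from compound 1 to compound 3 (0.01 log units; that floor lies within the scatter) and an at least 1.2-fold higher number from compound 2 to compound 3 (0.10 log units; that floor lies within the scatter) bear on this change, each being a swap of the aryl group on the carbonyl carbon; both were within the scatter, and compound 1 and compound 2 already mark where such variation lands. For compound 4 no step beyond the scatter is therefore expected, an at least 1.1-fold lower number from compound 3 to compound 4 (0.04 log units; that floor lies within the scatter). The estimate for compound 4 is 90000 nM, between 40000 nM and 200000 nM, with a fair chance that only a limit is reported again.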

Compound 4, half-maximal inhibitory concentration: > 100000 nM
Compound 4 gave a limit, no number (the forecaster's own chance of this, stated with the estimate: 45%); at least 1.1-fold (0.04 log units) between middle value and limit.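

The 2-chloropyridin-3-yl group extends the flat picture at the carbonyl carbon to a fourth aryl group: the steps of an at least 1.2-fold higher number from compound 2 to compound 4 (0.10 log units; that floor lies within the scatter) and an at least 1.0-fold higher number from compound 1 to compound 4 (0.01 log units; that floor lies within the scatter) are floors only, and neither separates compound 4 from its measured relatives. The step between compound 3 and compound 4 cannot be read because both values are limits of the assay and not numbers: the limit of > 100000 nM in this assay, at which 2 of the 4 values shown sit. With compound 3 and compound 4 both at that limit in this assay, none of the swaps of the aryl group on the carbonyl carbon among these four compounds gives a readable step beyond the scatter.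

On these data alone, it stays open whether a group of another kind on the carbonyl carbon, such as a piperidine ring or an aryl ring carrying a carboxylic acid, would give a step beyond the scatter in this assay. Equally open, as far as these compounds go, is whether changes elsewhere on the shared core, rather than at this amide, would bring the values well clear of the limit.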